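A few compounds are considered here, and "the series" means these few. Any claim that something is new, unique, unknown or untested is made for them only; others in the source may bear on it.

Measured in a functional assay on VCaP cells (Homo sapiens) for antiproliferative activity, read by CCK-8 assay, with a stated time of 6 days; on this read-out lower numbers stand for stronger inhibition and higher numbers for weaker inhibition:
compound 1 `CCN(c1ccc(C#N)c(Cl)c1)c1cc(-c2ccco2)ccc1C`: > 30000 nM (a limit)
compound 2 `CCN(c1ccc(C#N)c(Cl)c1)c1cc(-c2ccccc2)ccc1C`: > 30000 nM (a limit)

Compound 2 stands only at a limit, > 30000 nM, and no number is available for it. Compound 3 `CCN(c1ccc(C#N)c(Cl)c1)c1cc(C2=CCCCC2)ccc1C` carries the next change: cyclohex-1-en-1-yl in place of phenyl on an aromatic carbon. For the measured compounds named here, the one measured step that bears on it is a step that the two limits leave unreadable from compound 1 to compound 2, a swap at the same carbon, and it gives no size. Compound 1 and compound 2 both sit at the limit of > 30000 nM in this assay, at which 2 of the 2 values shown sit. Neither ring tried at this place has given a number, so no gain is expected in this assay, and a report as a limit is the likeliest outcome. The expected step is a number no higher from compound 2 to compound 3 (the limit leaves the size open), none beyond the scatter. For compound 3 the estimate is 30000 nM, with an expected range from 10000 nM to 60000 nM.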

Compound 3, half-maximal inhibitory concentration: 20000 nM
Estimate against measurement, compound 3: 1.5-fold (0.18 log units) above; the range from low to high includes it.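

In this assay compound 3 gives 20000 nM, a number rather than a limit, so this position, on an aromatic carbon para to a methyl group, can carry cyclohex-1-en-1-yl and still give a reading. From the compounds shown here alone, the comparisons are an at least 1.5-fold lower number from compound 2 to compound 3 (0.17 log units; that floor lies within the scatter) and an at least 1.5-fold lower number from compound 1 to compound 3 (0.17 log units; that floor lies within the scatter); both are floors, so their true sizes remain unknown, and neither floor establishes a change beyond the scatter. The two aromatic rings, phenyl and furan-2-yl, remain at a limit of the assay: the limit of > 30000 nM in this assay, at which 2 of the 3 values shown sit.

The compounds shown leave open how far compound 3 actually lies from compound 2 and compound 1, since only floors are available. Also open, going by these compounds, is whether a saturated cyclohexyl ring, a piperidine amine or a carboxylic acid on this carbon would give a number in this assay.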